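Shortening the side chain on compound 2

The source may hold more compounds than are shown below. What is called first, only, known or untested is meant among the compounds shown, and "the series" means these compounds.

Compound 2 `Cc1ccc(-c2cnc(N(CCCOc3ccccc3)Cc3ccc(C(=O)NO)cc3)s2)cc1` has, on the nitrogen attached to the shared core, a benzyl arm carrying the hydroxamic acid and a second arm ending in a phenoxy group. In a functional assay on HCT-116 cells (Homo sapiens) for antiproliferative activity, read by MTT assay, with a stated time of 48 h (on this read-out lower numbers stand for stronger inhibition of growth and higher numbers for weaker inhibition of growth), compound 2 gives 4140 nM, the lowest of the two numbers measured here. Among the measured compounds shown here, its only neighbour is compound 1 `CCCCCN(Cc1ccc(C(=O)NO)cc1)c1ncc(-c2ccc(C)cc2)s1`, which in this assay gives 23300 nM; the single step of a 5.6-fold lower number from compound 1 to compound 2 (0.75 log units; beyond the scatter) is the one comparison available.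

Compound 3 `CCN(Cc1ccc(C(=O)NO)cc1)c1ncc(-c2ccc(C)cc2)s1` is compound 2 with the second arm cut down: hydrogen in place of phenoxymethyl on a saturated chain carbon, two bonds along the chain from a nitrogen on an aromatic ring. For the measured compounds named here, the shorter arm is now smaller than in compound 1, so that step does not match exactly, but it is the only guide, and it points toward a weaker result once the phenoxy group is gone. Compound 3 is therefore expected to give about 25000 nM in this assay, within 8000 nM to 70000 nM, a step of a 6.0-fold higher number from compound 2 to compound 3 (0.78 log units; beyond the scatter) estimated from compound 2.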

Compound 3, concentration for 50% growth inhibition: 6870 nM
Beside the measured number, compound 3's estimate is 3.6-fold (0.56 log units) above it; measured number outside the range, below it.
By their numbers in this assay, from the lowest: compounds 2 and 3 (each within the scatter of the next); then compound 1.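

In this assay, putting hydrogen in place of phenoxymethyl gives a step within the scatter (a 1.7-fold higher number from compound 2 to compound 3 (0.22 log units; within the scatter)), so compound 3 keeps a number on a par with compound 2 without any phenoxy group. Hydrogen in place of propyl at the same carbon gives a modest step beyond the scatter (a 3.4-fold lower number from compound 1 to compound 3 (0.53 log units; beyond the scatter)), so the ethyl arm of compound 3 and the much longer 3-phenoxypropyl arm of compound 2 both stand apart from compound 1, and arm length alone does not order these three compounds. Nothing available here explains this pattern.

Still open, on these data alone, is how an arm ending in an amine or a carboxylic acid would behave at this position. A plain methyl arm on the same nitrogen also remains to be seen.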